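The compounds below may be only part of what the source reports. "The series", "measured", "known", "first", "only" and "open" are said of these compounds alone.

The compounds are compared in an assay on CHO cells for displacement of a labelled ligand from prostaglandin E2 receptor EP1 subtype (Mus musculus), read by scintillation counting, with a stated time of 20 min; on this read-out lower numbers stand for stronger inhibition and higher numbers for weaker inhibition. Compound 1 `CCc1cccc(C[C@H](O)/C=C/[C@H]2COC(=O)N2CCSCCCC(=O)O)c1` gives 2400 nM. Compound 3 `CCCc1cccc(C[C@H](O)/C=C/[C@H]2CCC(=S)N2CCCCCCC(=O)O)c1` gives only a limit of the assay, > 10000 nM. Compound 2 `O=C(O)CCCSCCN1C(=O)SC[C@@H]1/C=C/[C@@H](O)Cc1ccccc1` likewise gives only a limit of the assay, > 10000 nM. Compound 2 thus stands at the limit of > 10000 nM in this assay, at which 2 of the 3 values shown sit, sharing that place with compound 3, while compound 1 alone gives a number. Compound 4 `CCc1cccc(C[C@H](O)/C=C/[C@H]2CSC(=O)N2CCSCCCC(=O)O)c1` differs from compound 2 by ethyl in place of hydrogen on an aromatic carbon. No measured pair differs in one place, so the size of this step is not shown directly. Compound 1, which carries the same ethyl group and gives 2400 nM, suggests an expected gain beyond the scatter. The step of an at least 2.8-fold lower number from compound 2 to compound 4 (0.45 log units; beyond the scatter) is expected to run toward stronger inhibition. Compound 4 is estimated at 3500 nM, with a range from 1200 nM to 10000 nM.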

Compound 4, inhibition constant: 4600 nM
Estimate against measurement, compound 4: 1.3-fold (0.12 log units) below, within the range that was stated.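

In this assay, for the compounds shown here, ethyl in place of hydrogen on the aromatic carbon gives an at least 2.1-fold lower number from compound 2 to compound 4 (0.33 log units; beyond the scatter), the first single change in this set that can be read. It shows that this place on the ring accepts ethyl and that the change runs toward stronger inhibition. Compound 2 gives only a limit, so the step fixes a direction and a minimum size, not a full size: the limit of > 10000 nM in this assay, at which 2 of the 4 values shown sit.

As far as these compounds go, whether a methoxy group or a chlorine atom at this place would give a lower or higher number stays open. So does the effect of ethyl elsewhere on the ring.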